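The source may report more compounds than this note shows. Statements on the series, on what has been measured and on what is new or still open speak of the compounds shown alone.

Working notes on the series

Compound 1 `Nc1scc(CN2CCN(c3ccc(Cl)cc3F)CC2)c1C(=O)c1ccc(Cl)cc1` carries a 4-chloro-2-fluorophenyl on an amine nitrogen in a ring. In an assay on CHO cells for displacement of a labelled ligand from adenosine receptor A1 (Homo sapiens), read by scintillation counting, with a stated time of 120 min, tested at 10 uM (on this read-out lower numbers stand for less inhibition and higher numbers for more inhibition at the one concentration tested (going by the name of the read-out)), compound 1 gives 0%. Compound 2 `Nc1scc(CN2CCN(c3ccc(OC(F)(F)F)cc3)CC2)c1C(=O)c1ccc(Cl)cc1` gives 0% in this assay, and compound 3 `Nc1scc(CN2CCN(C3CCCCCC3)CC2)c1C(=O)c1ccc(Cl)cc1` gives 0%. Compound 1 thus stands level with compounds 2 and 3 at the digits printed; the nearest is compound 2 and the furthest compound 3, with no change within the scatter in either case.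

The next compound, compound 4 `Nc1scc(CN2CCN(c3cccc4ccccc34)CC2)c1C(=O)c1ccc(Cl)cc1`, differs from compound 1 in one place: naphthalen-1-yl in place of 4-chloro-2-fluorophenyl on an amine nitrogen in a ring.

Among the measured compounds shown here, two measured steps bear on this replacement, both exchanges of the group on the same amine nitrogen in a ring: no change at the digits printed from compound 1 to compound 2 (within the scatter) and no change at the digits printed from compound 1 to compound 3 (within the scatter). The third step, no change at the digits printed from compound 2 to compound 3 (within the scatter), also shows no movement. An aryl, a haloaryl and a cycloheptyl at this position all leave the read-out at the same level, so no step beyond the scatter is expected from the entry of naphthalen-1-yl.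

The step from compound 1 to compound 4 is expected to be a number 2 percentage points higher from compound 1 to compound 4 (within the scatter). Compound 4 is therefore estimated at 2%, between -8% and 15%.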

Compound 4, a percentage reported as inhibition, at one concentration (the size of the read-out at that concentration, not a potency): 1%
For compound 4 the middle estimate is 1 percentage points above the measured one; the range from low to high includes it.
By their numbers in this assay, from the lowest: compounds 1, 2, 3 and 4 (each within the scatter of the next).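

Working notes, continued

In this assay, among the compounds shown here, naphthalen-1-yl on the amine nitrogen in a ring gives a number 1 percentage points higher from compound 1 to compound 4 (within the scatter) and a number 1 percentage points higher from compound 3 to compound 4 (within the scatter) and also a number 1 percentage points higher from compound 2 to compound 4 (within the scatter) as the three steps to the earlier compounds. The position therefore stays flat even with 2 six-membered aromatic rings of carbon only in the entering group and with no fluorine or chlorine on it, a case the single-ring aryl groups and the cycloheptyl did not cover. No measurement on hand explains this flat result.

With all four compounds level at the bottom of the read-out, nothing yet shows whether any group at this nitrogen can move it. On these data alone, a carboxylic acid, a primary amine or a longer alkyl chain at this position remains open, as does any change to the shared core.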